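This account rests on a few compounds, and the source may have more. Where it says the series, first, only, none or still open, it means among the compounds named here.

Measured in a functional assay on MCF7 cells (Homo sapiens) for antiproliferative activity, read by MTT assay, with a stated time of 48 h; on this read-out lower numbers stand for stronger inhibition and higher numbers for weaker inhibition:
- compound 1 `C=C1[C@H](OC(C)=O)[C@@H](OC(C)=O)[C@@H](OC(C)=O)C(C)(C)/C=C/[C@H](C)[C@H](OC(=O)c2ccccc2)[C@@]2(O)C[C@@](C)(O)[C@H](OC(C)=O)[C@@H]2[C@H]1OCC(C)C`: > 100000 nM (a limit)
- compound 2 `C=C1[C@H](OC(C)=O)[C@@H](OC(=O)C(C)(C)C)[C@@H](OC(C)=O)C(C)(C)/C=C/[C@H](C)[C@H](OC(=O)c2ccccc2)[C@@]2(O)C[C@@](C)(O)[C@H](OC(C)=O)[C@@H]2[C@H]1OCC(C)C`: > 100000 nM (a limit)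
- compound 3 `C=C1[C@H](OC(C)=O)[C@@H](OC(=O)C(C)(C)C)[C@@H](OC(C)=O)C(C)(C)/C=C/[C@H](C)[C@H](OC(=O)c2ccccc2)[C@@]2(O)C[C@@](C)(OC(C)=O)[C@H](OC(C)=O)[C@@H]2[C@H]1OCC(C)C`: > 100000 nM (a limit)

Compound 3 gives no number, only a limit. The other two compounds are reported in the same way, so the whole set sits at the limit of > 100000 nM in this assay, at which 3 of the 3 values shown sit.

Compound 4 `C=C1[C@H](OC(C)=O)[C@@H](OC(C)=O)[C@@H](OC(C)=O)C(C)(C)/C=C/[C@H](C)[C@H](OC(=O)c2ccccc2)[C@@]2(O)C[C@@](C)(OC(C)=O)[C@H](OC(C)=O)[C@@H]2[C@H]1OCC(C)C` differs from compound 3 in a single place: methyl in place of tert-butyl on a carbonyl carbon. This is methyl in place of tert-butyl on a carbonyl carbon. The reverse exchange has been measured once, on a compound carrying a free hydroxyl, as a step that the two limits leave unreadable from compound 1 to compound 2. Among the measured compounds shown here, the only other measured step, acetyl in place of hydrogen on an oxygen on a saturated carbon, is a step that the two limits leave unreadable from compound 2 to compound 3. Both ends of each step are limits, so neither supplies a size that can be carried over.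

In this assay, therefore, no clear shift in either direction is expected, and compound 4 is expected to remain in the same region as the others, quite possibly reported as a limit again. The expected change is a step that the limit leaves unreadable from compound 3 to compound 4. The estimate for compound 4 is 130000 nM, with the value expected to fall between 50000 nM and 300000 nM.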

Compound 4, half-maximal inhibitory concentration: 74300 nM
Compound 4: middle estimate off by 1.7-fold (0.24 log units), on the high side; measured number inside the range.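

In this assay, among the compounds shown here, the exchange of (tert-butyl)carbonyl for acetyl yields the only number in the set, and the change reads as an at least 1.3-fold lower number from compound 3 to compound 4 (0.12 log units; that floor lies within the scatter). Acetyl in place of hydrogen on the oxygen of the free hydroxyl also becomes readable for the first time, as an at least 1.3-fold lower number from compound 1 to compound 4 (0.12 log units; that floor lies within the scatter). Both figures are floors lying within the scatter, so neither establishes a real gain, the steps linking compound 1, compound 2 and compound 3 cannot be read, and the true size of each new step stays unknown because the remaining compounds give no number: the limit of > 100000 nM in this assay, at which 3 of the 4 values shown sit.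

The compounds shown leave open whether any acyl group at this position can bring the number clearly beyond the scatter, for instance a longer chain such as hexanoyl or a chain ending in an amine or a carboxylic acid. They also leave open whether the two acetyl groups in compound 4 each contribute to its measurable value, or whether one of them alone would suffice on the shared core.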